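The source may hold more compounds than are shown below. What is called first, only, known or untested is meant among the compounds shown, and "the series" means these compounds.

Measured compounds:
- compound 1 `Cc1ccccc1COc1ccc(-c2cc(CN3CCN(Cc4ccc(C(F)(F)F)cc4)CC3)no2)cc1`, in a functional assay on Mahlavu cells (Homo sapiens) for antiproliferative activity, read by sulforhodamine B assay, with a stated time of 72 h (on this read-out lower numbers stand for stronger inhibition and higher numbers for weaker inhibition), compound 1 gives 6800 nM
- compound 2 `FC(F)(F)c1ccc(CN2CCN(Cc3cc(-c4ccc(OCc5cccc(Cl)c5)cc4)on3)CC2)cc1`, compound 2 gives 4100 nM
- compound 3 `N#Cc1ccc(COc2ccc(-c3cc(CN4CCN(Cc5ccc(C(F)(F)F)cc5)CC4)no3)cc2)cc1`, compound 3 gives 4300 nM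

All three share one core and differ only in the aryl group on the saturated chain carbon bound to an oxygen on an aromatic ring. Compound 3 holds the second highest of the three numbers in this assay; its nearest neighbour is compound 2, a 1.0-fold higher number from compound 2 to compound 3 (0.02 log units; within the scatter), and its furthest is compound 1, a 1.6-fold lower number from compound 1 to compound 3 (0.20 log units; within the scatter). Neither gap lies beyond the scatter, so no ordering among the three can be read.

The next compound, compound 4 `COc1cccc(COc2ccc(-c3cc(CN4CCN(Cc5ccc(C(F)(F)F)cc5)CC4)no3)cc2)c1`, changes this same aryl group: 3-methoxyphenyl in place of 4-cyanophenyl on a saturated chain carbon bound to an oxygen on an aromatic ring. Every measured step at this place bears on it: a 1.7-fold lower number from compound 1 to compound 2 (0.22 log units; within the scatter), a 1.6-fold lower number from compound 1 to compound 3 (0.20 log units; within the scatter), a 1.0-fold higher number from compound 2 to compound 3 (0.02 log units; within the scatter). All three swaps at this position stayed within the scatter. The expectation is therefore a further step of no size beyond the scatter, a 1.0-fold higher number from compound 3 to compound 4 (0.02 log units; within the scatter). Compound 4 is expected to give about 4500 nM in this assay, within a range of 2000 nM to 10000 nM.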

Compound 4, half-maximal inhibitory concentration: 1400 nM
Compound 4: the middle estimate sits 3.2-fold (0.51 log units) above what was measured; the whole stated range lies above it.
By their numbers in this assay, from the lowest: compound 4; then compounds 2, 3 and 1 (each within the scatter of the next).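

The aryl group on the saturated chain carbon bound to an oxygen on an aromatic ring can move the read-out in this assay: 3-methoxyphenyl stands apart from 4-cyanophenyl, with a 3.1-fold lower number from compound 3 to compound 4 (0.49 log units; beyond the scatter), and from 2-methylphenyl, with a 4.9-fold lower number from compound 1 to compound 4 (0.69 log units; beyond the scatter). Methoxy in place of chloro on an aromatic carbon also gives a step beyond the scatter, a 2.9-fold lower number from compound 2 to compound 4 (0.47 log units; beyond the scatter), so this position responds to a change of a single ring substituent, which none of the three earlier swaps showed. Nothing available accounts for this step.

On these data alone, whether the step belongs to the methoxy group itself or to its place on the ring remains open, and 4-methoxyphenyl would bear on that. Also open, as far as these compounds go, is whether an ethoxy or a hydroxy group in place of the methoxy would keep the lower number of compound 4.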